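Same Atoms, One Centre Redrawn: Solubility of Compound 4

The source may report more compounds than this note shows. Statements on the series, on what has been measured and on what is new or still open speak of the compounds shown alone.

Measured in a physicochemical assay for solubility, measured as kinetic solubility; a higher number here means a more soluble compound, a lower number a less soluble compound:
- compound 1 `Cc1cc(C)c(CN2CCc3c(Cl)cc([C@H](CO)[C@H]4CCOC4)c(Cl)c3C2=O)c(=O)[nH]1`: 570000 nM
- compound 2 `COC(c1cc(Cl)c2c(c1Cl)C(=O)N(Cc1c(C)cc(C)[nH]c1=O)CC2)C1CCS(=O)(=O)CC1`: 373000 nM; 415000 nM (2 entries)
- compound 3 `Cc1cc(C)c(CN2CCc3c(Cl)cc([C@@H](CO)[C@@H]4CCCO4)c(Cl)c3C2=O)c(=O)[nH]1`: 550000 nM

These numbers all lie close together. Compound 3, at 550000 nM, stands level with compound 1, since the gap between them lies within the scatter of repeated measurements. Repeats of a single compound also differ a little, as shown by the several entries of compound 2 in this assay, 373000 nM; 415000 nM (2 entries).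

The next compound is compound 4 `Cc1cc(C)c(CN2CCc3c(Cl)cc([C@@H](CO)[C@H]4CCCO4)c(Cl)c3C2=O)c(=O)[nH]1`. Its relation to compound 3 is simple: the two compounds have the same atoms and bonds and differ only in configuration as drawn: 1 of 2 stereo elements differ; a stereocentre at a saturated ring carbon is drawn S in compound 3 and R in compound 4. Nothing is added or removed, and only that one centre is drawn differently.

For the measured compounds named here, no measured pair isolates such a change. The nearest evidence is a 1.0-fold lower number from compound 1 to compound 3 (0.02 log units; within the scatter), which exchanged one side group carrying a five-membered non-aromatic ring for another. Even that change left this assay within the scatter, so a smaller edit that keeps every atom and bond gives no reason to predict a real shift in either direction.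

The expected change is a 1.1-fold lower number from compound 3 to compound 4 (0.02 log units; within the scatter), which would be no step beyond the scatter. For compound 4 the estimated value is 520000 nM, with an expected range from 330000 nM to 800000 nM.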

Compound 4, solubility: 576000 nM
Compound 4: middle estimate off by 1.1-fold (0.04 log units), on the low side; the measured number falls inside the stated range.
By their numbers in this assay, from the lowest: compounds 3, 1 and 4 (each within the scatter of the next).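

For the compounds shown here, compound 3 and compound 4 form the first measured pair here in which only a stereocentre at a saturated ring carbon is redrawn, and in this assay that edit gives a 1.0-fold higher number from compound 3 to compound 4 (0.02 log units; within the scatter). Exchanging one group of 8 heavy atoms, carrying a five-membered non-aromatic ring with 1 hetero atom, for another of the same count gives a 1.0-fold higher number from compound 1 to compound 4 (0.00 log units; within the scatter), so compound 1, compound 3 and compound 4 now stand level in this measurement. Repeat entries of a single compound also differ, so a step of this size cannot be told apart from repeat measurement: the several entries of compound 2 in this assay, 373000 nM; 415000 nM (2 entries)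

On these data alone, the other stereo element, drawn alike in compound 3 and compound 4, has not been isolated in a measured pair, so the outcome of redrawing it alone remains open. As far as these compounds go, it also remains open whether this level holds once the side group on that aromatic carbon carries an amine or a carboxylic acid in place of the groups seen here.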